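Swapping the Methylphenyl Group on Two Related Cores

A few compounds are considered here, and "the series" means these few. Any claim that something is new, unique, unknown or untested is made for them only; others in the source may bear on it.

Measured in an assay on isolated protein for inhibition of Long-chain-fatty-acid--CoA ligase 1 (Mus musculus), read by mass spectrometry, with a stated time of 90 min, in the presence of a further agent that is not named here; a lower number here means a stronger inhibitor, a higher number a weaker inhibitor:
Compound 1, `Cc1cccc(Cc2nc3cc(O[C@H]4CC[C@@H](C(=O)O)CC4)ccc3n2C)c1`, gives 30 nM.
Compound 2, `Cn1c(Cc2ccc3c(c2)OCC3)nc2cc(O[C@H]3CC[C@@H](C(=O)O)CC3)ccc21`, gives 36 nM.
Compound 3, `Cc1cccc(Cc2nc3cc(O[C@H]4CC[C@@](F)(c5nnn[nH]5)CC4)ccc3n2C)c1`, gives 13 nM.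

Compound 4, `Cn1c(Cc2ccc3c(c2)OCC3)nc2cc(O[C@H]3CC[C@@](F)(c4nnn[nH]4)CC3)ccc21`, has not yet been measured in this assay. It is related to compound 3 by the same change that relates compound 1 to compound 2, namely (a group of 9 heavy atoms (8 carbon, 1 oxygen; one five-membered non-aromatic ring with 1 hetero atom, one six-membered aromatic ring of carbon only) in place of a group of 7 heavy atoms (7 carbon; one six-membered aromatic ring of carbon only), on a saturated chain carbon bound to an aromatic carbon). On the core of compound 3 this change is a group of 9 heavy atoms (8 carbon, 1 oxygen; one five-membered non-aromatic ring with 1 hetero atom, one six-membered aromatic ring of carbon only) in place of a group of 7 heavy atoms (7 carbon; one six-membered aromatic ring of carbon only), on a saturated chain carbon bound to an aromatic carbon. The difference between the core of compound 1 and the core of compound 3 is not broken down here. The measured step of a 1.2-fold higher number from compound 1 to compound 2 (0.08 log units; within the scatter) stayed within the scatter. Compound 3 gives a number lower than compound 1 and compound 2 by steps beyond the scatter. Because the same change on the core of compound 1 gave a 1.2-fold higher number from compound 1 to compound 2 (0.08 log units; within the scatter), compound 4 is expected to show a 1.2-fold higher number from compound 3 to compound 4 (0.09 log units; within the scatter). Compound 4 is therefore estimated at 16 nM, likely between 7 nM and 36 nM.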

Compound 4, half-maximal inhibitory concentration: 15 nM
Estimate against measurement, compound 4: 1.1-fold (0.03 log units) above, within the range that was stated.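

In this assay, putting the group with the oxygen-containing five-membered ring in place of 3-methylphenyl on the fluorinated tetrazole-bearing core gave a 1.2-fold higher number from compound 3 to compound 4 (0.06 log units; within the scatter). The same change therefore reads alike on both cores, and the two steps cannot be told apart: the same change on two cores in this assay, a 1.2-fold higher number (0.08 log units; within the scatter) from compound 1 to compound 2 and a 1.2-fold higher number (0.06 log units; within the scatter) from compound 3 to compound 4, 1.0-fold (0.02 log units) apart, within the scatter of two such steps

For the compounds shown here, this shows that the swap left the number essentially unmoved on these two cores, but it rests on only one pair per core, and a step within the scatter cannot show how a larger effect would carry over. Still open, on these data alone, is whether an amine on that same saturated chain carbon would shift the number beyond the scatter. As far as these compounds go, how the swap would read on a third core is also open.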